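Trimethoxyphenyl pyrazole chalcones: adding a methoxy group

A few compounds are considered here, and "the series" means these few. Any claim that something is new, unique, unknown or untested is made for them only; others in the source may bear on it.

This study compares a small set of pyrazole-linked chalcones in a functional assay on NCI-H226 cells (Homo sapiens) for inhibition, read by sulforhodamine B assay, with a stated time of 48 h; on this read-out higher numbers stand for weaker inhibition of growth and lower numbers for stronger inhibition of growth. Compound 1 `COc1ccc(-c2cc(/C=C/C(=O)c3ccc(N)cc3)[nH]n2)cc1` gives 5570 nM in this assay. Compound 3 `COc1ccc(-c2cc(/C=C/C(=O)c3ccc(N)cc3)[nH]n2)cc1OC` differs from compound 1 by methoxy in place of hydrogen on an aromatic carbon. In this assay compound 3 gives 7380 nM; the step of a 1.3-fold higher number from compound 1 to compound 3 (0.12 log units; within the scatter). Compound 2 `COc1ccc(C(=O)/C=C/c2cc(-c3cc(OC)c(OC)c(OC)c3)n[nH]2)cc1OC` is built on a different core, and the difference between the two cores is not broken down here; in this assay compound 2 gives 3320 nM. The gap from compound 2 to compound 1 lies within the scatter, while the gap from compound 2 to compound 3 lies beyond it, so no firm order among the three can be claimed.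

Compound 4 `COc1cc(C(=O)/C=C/c2cc(-c3cc(OC)c(OC)c(OC)c3)n[nH]2)cc(OC)c1OC` is not yet measured. It differs from compound 2 by methoxy in place of hydrogen on an aromatic carbon. Among the compounds with values here, this is the same kind of change as the one from compound 1 to compound 3, although the surroundings are not identical: on compound 4 the entering methoxy group is also meta to a methoxy group, which is not the case on compound 3. Given that the same kind of change from compound 1 to compound 3 moved the number by a 1.3-fold higher number from compound 1 to compound 3 (0.12 log units; within the scatter), the step from compound 2 to compound 4 is expected to be a 1.3-fold higher number from compound 2 to compound 4 (0.10 log units; within the scatter) in this assay. On that basis compound 4 is estimated to give about 4200 nM in this assay, most likely between 1500 nM and 12000 nM.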

Compound 4, concentration for total growth inhibition: 3050 nM
For compound 4 the middle estimate is 1.4-fold (0.14 log units) above the measured one, and the stated range covers the measured number.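

In this assay, putting methoxy in place of hydrogen on an aromatic carbon of the core of compound 2 gives a 1.1-fold lower number from compound 2 to compound 4 (0.04 log units; within the scatter). Set beside the same change on the core of compound 1, the two steps cannot be told apart: the same change on two cores in this assay, a 1.3-fold higher number (0.12 log units; within the scatter) from compound 1 to compound 3 and a 1.1-fold lower number (0.04 log units; within the scatter) from compound 2 to compound 4, 1.4-fold (0.16 log units) apart, within the scatter of two such steps. Within the data shown here, this shows that, in these two pairs, the change leaves the number within the scatter on either core, so the result on one core gave no sign of a different outcome on the other; it does not show that the step carries over generally, since it rests on only two pairs, neither step is large enough to be read as a real shift, and the entering methoxy group stands in different surroundings on the two cores.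

The compounds shown leave open whether a group other than methoxy at this place, such as a hydroxyl group, a chlorine atom or a longer chain like ethoxy, would move the number beyond the scatter. They also leave open whether the near-absence of a step would persist on a third core, or in any read-out other than this assay.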